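This account rests on a few compounds, and the source may have more. Where it says the series, first, only, none or still open, it means among the compounds named here.

Measured compounds so far:
- compound 1 `COc1ccc(-c2sc(N)c(C(=O)c3ccc(Cl)cc3)c2C)cc1`: 1%
- compound 2 `Cc1sc(N)c(C(=O)c2ccc(Cl)cc2)c1-c1ccccc1`: 1%
- compound 3 `CC(C)(C)Cc1c(-c2ccccn2)sc(N)c1C(=O)c1ccc(Cl)cc1`: 1%

In an assay on CHO cells for displacement of a labelled ligand from adenosine receptor A3 (Homo sapiens), read by scintillation counting, tested at 10 uM (on this read-out lower numbers stand for less inhibition and higher numbers for more inhibition at the one concentration tested (going by the name of the read-out)), compound 1 gives 1%, compound 2 gives 1% and compound 3 gives 1%. Among the measured compounds shown here, all three sit at the same figure, within the scatter of each other, so no compound of this set stands apart in this assay. Compound 4 `CC(C)(C)Cc1c(-c2ccco2)sc(N)c1C(=O)c1ccc(Cl)cc1` is not yet measured. It differs from compound 3 as follows: furan-2-yl in place of pyridin-2-yl on an aromatic carbon. For the measured compounds named here, no step between measured compounds is known, so the size of the step from compound 3 to compound 4 cannot be taken from any measured pair. With every measured compound at the same low figure, no movement beyond the scatter is expected; the step of a number 1 percentage points higher from compound 3 to compound 4 (within the scatter) is expected to be nil. Compound 4 is expected to give about 2% in this assay, between 0% and 12%.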

Compound 4, a percentage reported as inhibition, at one concentration (the size of the read-out at that concentration, not a potency): 1%
Compound 4: the middle estimate sits 1 percentage points above what was measured; measured number inside the range.
By their numbers in this assay, from the lowest: compounds 1, 2, 3 and 4 (each within the scatter of the next).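

In this assay, furan-2-yl in place of pyridin-2-yl on the aromatic carbon next to the ring sulfur gives no change at the digits printed from compound 3 to compound 4 (within the scatter) with the neopentyl group kept. Among the compounds shown here, this pair gives the first reading at this position: here, a five-membered and a six-membered aromatic ring, each with 1 hetero atom, cannot be told apart. No available evidence bears on this result.

On these data alone, whether any group at this position can raise the figure remains open. A carboxylic acid or an aminomethyl group there would test this.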